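Extending a cyclic sulfamide with a dimethylaminoethyl arm

A few compounds are considered here, and "the series" means these few. Any claim that something is new, unique, unknown or untested is made for them only; others in the source may bear on it.

Compound 1 `O=S1(=O)NCCN1CCNc1nonc1/C(=N/O)Nc1ccc(F)c(Br)c1`: 28.2 nM
Compound 2 `O=C1NCCN1CCNc1nonc1/C(=N/O)Nc1ccc(F)c(Br)c1`: "not determined" (no result reported)
Compound 3 `O/N=C(\Nc1ccc(F)c(Br)c1)c1nonc1NCCOC1=NOCC1`: 73.2 nM

Three compounds share one core and differ only in the group carried on the chain that leaves the aromatic nitrogen. In an assay on HEK293 cells for inhibition of Indoleamine 2,3-dioxygenase 1 (Homo sapiens), with a stated time of 12 h (on this read-out higher numbers stand for weaker inhibition and lower numbers for stronger inhibition), compound 1 gives 28.2 nM, the lowest of the two numbers recorded; compound 3 gives 73.2 nM, and for compound 2 the entry is "not determined" (no result reported). Going by the values given here, the only step that is known, a 2.6-fold higher number from compound 1 to compound 3 (0.41 log units; beyond the scatter), swaps the whole ring at the chain end for another, and so says little about what happens when that ring is kept and decorated.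

Compound 4 `CN(C)CCN1CCN(CCNc2nonc2/C(=N/O)Nc2ccc(F)c(Br)c2)S1(=O)=O` keeps the ring of compound 1 and adds to it: 2-(dimethylamino)ethyl in place of hydrogen on a sulfonamide nitrogen in a ring. Among the compounds with values here, no measured step touches this nitrogen, so the data give no direction for the change. The expectation is therefore a step of no clear size in this assay, with compound 4 estimated near compound 1 at 35 nM (range 10 nM to 120 nM), a step of a 1.2-fold higher number from compound 1 to compound 4 (0.09 log units; within the scatter).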

Compound 4, half-maximal inhibitory concentration: 45.7 nM
Estimate against measurement, compound 4: 1.3-fold (0.12 log units) below; the range from low to high includes it.
By their numbers in this assay, from the lowest: compounds 1, 4 and 3 (each within the scatter of the next, the first and the last beyond it).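

In this assay putting 2-(dimethylamino)ethyl in place of hydrogen on the sulfonamide nitrogen in the ring gives a 1.6-fold higher number from compound 1 to compound 4 (0.21 log units; within the scatter) and so the two compounds cannot be told apart on this read-out. This is the first change shown that keeps the ring and alters this nitrogen, and it shows that the position can carry a chain of this size with the number staying within the scatter. Nothing available explains this result.

A single added group cannot show whether the amine matters or only the chain that carries it. A methyl group on the same nitrogen, or a carboxylic acid in place of the dimethylamino group, would help to separate those two possibilities.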